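A few compounds are considered here, and "the series" means these few. Any claim that something is new, unique, unknown or untested is made for them only; others in the source may bear on it.

In a functional assay on Granta-519 cells (Homo sapiens) for inhibition, read by trypan blue exclusion, with a stated time of 72 h (a higher number here means a weaker inhibitor of growth, a lower number a stronger inhibitor of growth), the measured compounds stand as follows

compound 1 (`Cn1c(=O)c(S(=O)(=O)c2ccc(OC(=O)CCCCC3SCC4NC(=O)NC43)cc2)cc2cnc(Nc3ccc4[nH]ccc4c3)nc21`) gives 500 nM
compound 2 (`Cn1c(=O)c(S(=O)(=O)c2ccc(F)cc2)cc2cnc(Nc3ccc4[nH]ccc4c3)nc21`) gives 60 nM

Compound 2 holds the lowest of the two numbers, and its gap to compound 1 lies beyond the scatter.

Compound 3 (`Cn1c(=O)c(S(=O)(=O)c2ccc(O)cc2)cc2cnc(Nc3ccc4[nH]ccc4c3)nc21`) has not yet been measured. It differs from compound 2 by a single swap (hydroxy in place of fluoro on an aromatic carbon), with hydroxy in place of fluoro on an aromatic carbon, para to a large group. Among the compounds with values here, no measured pair shows this swap, so the expectation starts from compound 2 at 60 nM and stays cautious. The expected step (a 1.3-fold higher number from compound 2 to compound 3 (0.12 log units; within the scatter)) is small, towards a somewhat weaker inhibitor of growth in this assay and possibly within the scatter. For compound 3 an estimated 80 nM is expected, with 30 nM to 250 nM as the expected range.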

Compound 3, concentration for 50% growth inhibition: 250 nM
Beside the measured number, compound 3's estimate is 3.1-fold (0.49 log units) below it, and the stated range covers the measured number.
By their numbers in this assay, from the lowest: compound 2; then compounds 3 and 1 (each within the scatter of the next).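

In this assay the swap of fluoro for hydroxy on this aromatic carbon, para to a large group, gives a weaker inhibitor of growth (a 4.2-fold higher number from compound 2 to compound 3 (0.62 log units; beyond the scatter)). Within the data shown here, this is the first single-place change that can be read, and it shows that growth inhibition responds to the exchange of one heavy atom at this position. The entering hydroxy counts one hydrogen-bond donor and one hydrogen-bond acceptor where the leaving fluoro counts neither, but no measurement at hand bears on what lies behind the step.

Going by these compounds, whether an amine or a methoxy group on the same carbon would stand closer to compound 2 or to compound 3 remains open. A single pair also leaves open how a carboxylic acid or a longer chain would read at this position.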